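A few compounds are considered here, and "the series" means these few. Any claim that something is new, unique, unknown or untested is made for them only; others in the source may bear on it.

Measured so far in an assay on isolated protein for inhibition of protein deacetylase HDAC6 (Homo sapiens), read by fluorescence, with a stated time of 15 min; on this read-out lower numbers stand for stronger inhibition and higher numbers for weaker inhibition:
compound 1 `Cc1ccc(-c2cc(/C=C/c3ccc(C(=O)NO)cc3)ccn2)cc1`, 150 nM
compound 2 `Cc1ccc(-c2cc(/C=C/c3ccc(C(=O)NO)cc3)ccn2)c(F)c1`, 15 nM
compound 3 `Cc1ccc(-c2cncc(/C=C/c3ccc(C(=O)NO)cc3)c2)c(F)c1`, 150 nM

On these numbers compound 3 sits level with compound 1 at the digits shown, and the two of them together give the highest numbers of the three, meaning the weakest inhibition seen. Among the compounds with values here, compound 2 gives the lowest number, and the only single-place step among the measured compounds is a 10-fold lower number from compound 1 to compound 2 (1.00 log units; beyond the scatter), a fluoro added to the aromatic ring of compound 1.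

Compound 4 `COc1ccc(F)cc1-c1cncc(/C=C/c2ccc(C(=O)NO)cc2)c1` is reached from compound 3 by 5-fluoro-2-methoxyphenyl in place of 2-fluoro-4-methylphenyl on an aromatic carbon. Within the data shown here, no measured pair shows this swap of one substituted phenyl for another. The step from compound 1 to compound 2 involves a fluoro on a different core and with the methyl kept, so it does not carry over directly. The expectation is therefore for a change in this assay of about a 1.3-fold higher number from compound 3 to compound 4 (0.12 log units; within the scatter), with little confidence in its direction. For compound 4 the estimated value is 200 nM, within a range of 50 nM to 800 nM.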

Compound 4, half-maximal inhibitory concentration: 93 nM
For compound 4 the middle estimate is 2.2-fold (0.33 log units) above the measured one, and the stated range covers the measured number.
By their numbers in this assay, from the lowest: compound 2; then compounds 4, 1 and 3 (each within the scatter of the next).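

In this assay, 5-fluoro-2-methoxyphenyl in place of 2-fluoro-4-methylphenyl gives a 1.6-fold lower number from compound 3 to compound 4 (0.21 log units; within the scatter), so the two compounds cannot be told apart in this test. This aromatic carbon, two atoms from the ring nitrogen, therefore carries a phenyl group with a methoxy group instead of a methyl group and a differently placed fluoro, with no difference beyond the usual scatter. No measurement is available here that would explain this result.

The two phenyl groups differ in more than one feature, so the separate contributions of the methoxy group and the placement of the fluoro remain unresolved. Going by these compounds, it also remains open whether this position would accept a phenyl group carrying an amine or a carboxylic acid as readily.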